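Swapping a phenyl for a methoxy on a quinoline amide

A few compounds are considered here, and "the series" means these few. Any claim that something is new, unique, unknown or untested is made for them only; others in the source may bear on it.

Going by the values given here, the three compounds measured so far share one core and differ only in the group attached to the ring that carries the nitrogen. Compound 1 `CC(C)(C)n1cc2c(n1)C(=O)CC1(CCN(C(=O)c3cc(-c4ccccc4)nc4ccccc34)CC1)O2` gives 2110 nM in a functional assay on HepG2 cells (Homo sapiens) for inhibition, read by MTT assay, with a stated time of 72 h (on this read-out higher numbers stand for weaker inhibition and lower numbers for stronger inhibition), which places it second highest of the three numbers. Compound 2 `COc1ccc(-c2cc(C(=O)N3CCC4(CC3)CC(=O)c3nn(C(C)(C)C)cc3O4)c3ccccc3n2)cc1OC` gives 1560 nM, a change of a 1.4-fold lower number from compound 1 to compound 2 (0.13 log units; within the scatter), so the two are indistinguishable here. Compound 3 `Cc1cc(C(=O)N2CCC3(CC2)CC(=O)c2nn(C(C)(C)C)cc2O3)c2ccccc2n1` gives 9480 nM, and the step of a 4.5-fold higher number from compound 1 to compound 3 (0.65 log units; beyond the scatter) is the one clear difference in the set; the same holds for a 6.1-fold higher number from compound 2 to compound 3 (0.78 log units; beyond the scatter).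

Compound 4 `COc1cc(C(=O)N2CCC3(CC2)CC(=O)c2nn(C(C)(C)C)cc2O3)c2ccccc2n1` is the next candidate. Relative to compound 1 the change is methoxy in place of phenyl on an aromatic carbon. Among the compounds with values here, both informative steps so far show that shrinking the phenyl to a small group raises the number, as in a 4.5-fold higher number from compound 1 to compound 3 (0.65 log units; beyond the scatter). A methoxy is likewise small, so a modest rise is expected, giving an estimated step of a 3.3-fold higher number from compound 1 to compound 4 (0.52 log units; beyond the scatter). Compound 4 is therefore expected to give about 7000 nM, with a likely range from 3000 nM to 18000 nM.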

Compound 4, half-maximal inhibitory concentration: > 10000 nM
Compound 4 ended at the assay's limit; the forecaster's own chance of this, stated with the estimate: 5%; middle value at least 1.4-fold (0.15 log units) away from the limit.
By their numbers in this assay, from the lowest: compounds 2 and 1 (each within the scatter of the next); then compound 3. At a limit, above all of these: compound 4.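

In this assay compound 4 gives > 10000 nM, which is a limit of the assay and not a number: the limit of > 10000 nM in this assay, at which 1 of the 4 values shown sits.

Even so, the comparisons at this position can be read: an at least 4.7-fold higher number from compound 1 to compound 4 (0.67 log units; beyond the scatter), an at least 6.4-fold higher number from compound 2 to compound 4 (0.80 log units; beyond the scatter), and an at least 1.0-fold higher number from compound 3 to compound 4 (0.02 log units; that floor lies within the scatter). Methoxy, which brings an oxygen, therefore joins methyl in giving weaker inhibition than phenyl or 3,4-dimethoxyphenyl, while the floor of the last of these steps lies within the scatter, so methoxy and methyl cannot be put in order.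

The compounds shown leave open whether an aromatic ring itself is what matters here, or whether a non-aromatic ring such as cyclohexyl would serve as well. They also leave open how an amine or a longer chain such as butyl would behave at this position.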